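The source may report more compounds than this note shows. Statements on the series, on what has been measured and on what is new or still open speak of the compounds shown alone.

Measured in a functional assay on A-375 cells (Homo sapiens) for antiproliferative activity, read by trypan blue exclusion, with a stated time of 48 h, tested at 5 uM; on this read-out lower numbers stand for a stronger effect and higher numbers for a weaker effect at the one concentration tested:

- compound 1 `CCCCC#Cc1ccc(S(=O)(=O)Nc2cccc(-c3csc(NC(C)=O)n3)c2)cc1`: 9.3%
- compound 2 `C#Cc1ccc(S(=O)(=O)Nc2cccc(-c3csc(NC(C)=O)n3)c2)cc1`: 38.3%
- compound 3 `CCCCCCCCC#Cc1ccc(S(=O)(=O)Nc2cccc(-c3csc(NC(C)=O)n3)c2)cc1`: 8.9%

Compound 2 gives the highest number of the three in this assay, that is the weakest effect; the steps of a number 29 percentage points higher from compound 1 to compound 2 (beyond the scatter) and a number 29.4 percentage points lower from compound 2 to compound 3 (beyond the scatter) both lie beyond the scatter, while a number 0.4 percentage points lower from compound 1 to compound 3 (within the scatter) does not. Compound 4 `C#Cc1cccc(S(=O)(=O)Nc2cccc(-c3csc(NC(C)=O)n3)c2)c1` differs from compound 2 by 3-ethynylphenyl in place of 4-ethynylphenyl on a sulfonyl sulfur. Among the measured compounds shown here, no measured step touches this change: every measured step alters only what sits on the triple-bonded carbon, and the ring substitution pattern is untested. Without a comparable step, no shift beyond the scatter is expected, so a number 0.3 percentage points lower from compound 2 to compound 4 (within the scatter) is the estimate. Compound 4 is therefore expected to give about 38% in this assay, with a range from 20% to 60%.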

Compound 4, a percentage reported as activity, at one concentration (the size of the read-out at that concentration, not a potency): 29%
The estimate for compound 4 lay 9 percentage points above the measured number, within the range that was stated.
By their numbers in this assay, from the lowest: compounds 3 and 1 (each within the scatter of the next); then compounds 4 and 2 (each within the scatter of the next).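

In this assay, among the compounds shown here, 3-ethynylphenyl in place of 4-ethynylphenyl on a sulfonyl sulfur gives a number 9.3 percentage points lower from compound 2 to compound 4 (within the scatter) and is the first reading on the ring pattern, since the earlier steps altered only what sits on the triple-bonded carbon. With a hydrogen on the triple-bonded carbon, this rearrangement does not separate the two compounds at the one concentration tested. No evidence on hand bears on this result.

Open, as far as these compounds go, is whether the 3-ethynylphenyl pattern holds with the butyl and octyl chains of compound 1 and compound 3. Also open, from the compounds shown here alone, is how an amine or a carboxylic acid at the end of such a chain would read.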